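From 2-chlorophenyl to 4-methylphenyl: what to expect of compound 4

The source may report more compounds than this note shows. Statements on the series, on what has been measured and on what is new or still open speak of the compounds shown alone.

Compound 1 `C[C@H]1CC[C@@H]2[C@@H](OC(=O)[C@]23CC(c2ccccc2[N+](=O)[O-])=NO3)[C@]2(C)C(=O)C=C[C@@]12O`: 1.37
Compound 2 `COc1ccc(C2=NO[C@]3(C2)C(=O)O[C@@H]2[C@H]3CC[C@H](C)[C@]3(O)C=CC(=O)[C@@]23C)cc1OC`: 1.06
Compound 3 `C[C@H]1CC[C@@H]2[C@@H](OC(=O)[C@]23CC(c2ccccc2Cl)=NO3)[C@]2(C)C(=O)C=C[C@@]12O`: 2.09

In a physicochemical assay for lipophilicity (on this read-out higher numbers stand for higher lipophilicity and lower numbers for lower lipophilicity), compound 3 stands highest of the three, with a number 0.72 log units higher from compound 1 to compound 3 (beyond the scatter) and a number 1.03 log units higher from compound 2 to compound 3 (beyond the scatter). The next compound, compound 4 `Cc1ccc(C2=NO[C@]3(C2)C(=O)O[C@@H]2[C@H]3CC[C@H](C)[C@]3(O)C=CC(=O)[C@@]23C)cc1`, carries 4-methylphenyl in place of 2-chlorophenyl on a carbon with a double bond to nitrogen. Among the measured compounds shown here, no measured step swaps chloro for methyl, so the evidence is indirect. The steps at this place, a number 0.31 log units lower from compound 1 to compound 2 (beyond the scatter) and a number 1.03 log units higher from compound 2 to compound 3 (beyond the scatter), show that this assay responds to the group there, the second step being large. Compound 1 and compound 2 carry nitro or methoxy groups and lie lower, and neither group occurs in compound 3 or compound 4. Compound 4 is therefore expected to stay near compound 3, not to fall towards those two. The expected change is small, slightly downward and probably within the scatter: a number 0.19 log units lower from compound 3 to compound 4 (within the scatter). For compound 4 the estimated value is 1.9, with an expected range from 1.5 to 2.3.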

Compound 4, partition coefficient: 1.86
Compound 4: middle estimate off by 0.04 log units, on the high side; low and high end bracket the measured number.
By their numbers in this assay, from the lowest: compound 2; then compound 1; then compounds 4 and 3 (each within the scatter of the next).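

In this assay, among the compounds shown here, the exchange of 2-chlorophenyl for 4-methylphenyl gives a number 0.23 log units lower from compound 3 to compound 4 (within the scatter) and is the first step at this position that stays within the scatter, so the number does not separate these two groups. Compound 4 also stands clear of the two lower compounds, with a number 0.80 log units higher from compound 2 to compound 4 (beyond the scatter) and a number 0.49 log units higher from compound 1 to compound 4 (beyond the scatter) on the same side as compound 3, and among these four compounds the phenyl groups carrying nitro or methoxy lie lower, with none going against that. No measurement here accounts for these steps.

Since 2-chlorophenyl and 4-methylphenyl differ in both the substituent and its numbered place on the ring, the compounds shown do not separate those two changes, as 4-chlorophenyl or 2-methylphenyl could. They also leave open how the number would answer to an amine or a carboxylic acid on that ring.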